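Methoxy Added to the Phenyl Ring of Compound 1

The source may hold more compounds than are shown below. What is called first, only, known or untested is meant among the compounds shown, and "the series" means these compounds.

Among the compounds with values here, compound 1 `COc1cc(/C=C/C(=O)c2cccc(-n3cc(-c4ccccc4)[nH]c3=O)c2)ccc1O` is one of two compounds measured in a functional assay on NCI-H322M cells (Homo sapiens) for inhibition; a higher number here means a weaker inhibitor of growth, a lower number a stronger inhibitor of growth; in this assay compound 1 gives 3390 nM, the lower of the two numbers. Within the data shown here, its only neighbour, compound 2 `O=C(/C=C/c1cccc(O)c1)c1cccc(-n2cc(-c3ccccc3)[nH]c2=O)c1`, gives 10600 nM, and the step of a 3.1-fold higher number from compound 1 to compound 2 (0.50 log units; beyond the scatter) alters just the aryl group on the double-bonded chain carbon. Compound 3 `COc1ccc(-c2cn(-c3cccc(C(=O)/C=C/c4ccc(O)c(OC)c4)c3)c(=O)[nH]2)cc1` has not yet been measured. It differs from compound 1 by methoxy in place of hydrogen on an aromatic carbon. Among the measured compounds shown here, no measured step touches this ring: the single known step, from compound 1 to compound 2, changes the other aryl group, so the consequence of a methoxy on the phenyl is not yet informed by any measurement. The expectation is therefore a step no larger than the scatter, a 1.0-fold higher number from compound 1 to compound 3 (0.00 log units; within the scatter), held with a wide range. Compound 3 is estimated at 3400 nM, between 1400 nM and 8500 nM.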

Compound 3, concentration for 50% growth inhibition: 8200 nM
The estimate for compound 3 lay 2.4-fold (0.38 log units) below the measured number; low and high end bracket the measured number.
By their numbers in this assay, from the lowest: compound 1; then compounds 3 and 2 (each within the scatter of the next).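

In this assay the phenyl ring of compound 1 does respond to substitution: methoxy in place of hydrogen, on an aromatic carbon para to a large group, brings a 2.4-fold higher number from compound 1 to compound 3 (0.38 log units; beyond the scatter) and so a weaker inhibitor of growth. Within the data shown here, the only earlier step, a 3.1-fold higher number from compound 1 to compound 2 (0.50 log units; beyond the scatter), changed the other aryl group, so this is the first reading at this ring, and both changes made to compound 1 so far raise the number. Nothing measured here bears on why the methoxy has this result.

As far as these compounds go, whether this rise belongs to methoxy itself or to any group at this place remains open, and a fluorine, a methyl or an amine on the same carbon would tell these apart. Also open, from the compounds shown here alone, is whether the phenyl to 4-methoxyphenyl change would act in the same way alongside the 3-hydroxyphenyl group of compound 2.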